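This account rests on a few compounds, and the source may have more. Where it says the series, first, only, none or still open, it means among the compounds named here.

Working notes on the series.

Compound 1 `COc1ccc(C(=O)c2ccc(OC)c3c2OC(C)(C)C=C3)c(NC(=O)CN)c1` gives 410 nM in a functional assay on HeLa cells (Homo sapiens) for antiproliferative activity, read by MTT assay, with a stated time of 48 h; on this read-out higher numbers stand for weaker inhibition and lower numbers for stronger inhibition. Compound 2 `COc1ccc(C(=O)c2ccc(OC)c3c2C=CC(C)(C)O3)c(NC(=O)CN)c1` shares the same atoms joined differently; the difference between the two cores is not broken down here. In this assay compound 2 gives 100 nM, the lowest number among the three measured compounds and beyond the scatter relative to both others, so it is the strongest inhibitor so far. Compound 3 `CNCC(=O)Nc1cc(OC)ccc1C(=O)c1ccc(OC)c2c1OC(C)(C)C=C2` carries methyl in place of hydrogen on an amine nitrogen on the core of compound 1; in this assay compound 3 gives 870 nM, and the step of a 2.1-fold higher number from compound 1 to compound 3 (0.33 log units; beyond the scatter) is modest but beyond the scatter.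

Compound 4 `CNCC(=O)Nc1cc(OC)ccc1C(=O)c1ccc(OC)c2c1C=CC(C)(C)O2` applies the same kind of change to compound 2: methyl in place of hydrogen on an amine nitrogen. The place line reads the same in both cases, an amine nitrogen whose other neighbour is a saturated chain carbon. Within the data shown here, from compound 2 to compound 4 a step of a 2.1-fold higher number from compound 2 to compound 4 (0.32 log units; beyond the scatter) is expected, resting on the single earlier example, in which compound 1 to compound 3 gave a 2.1-fold higher number from compound 1 to compound 3 (0.33 log units; beyond the scatter); only one such pair exists, so the expectation is loosely held. Compound 4 is therefore estimated at 210 nM in this assay, within 100 nM to 450 nM.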

Compound 4, half-maximal inhibitory concentration: 2170 nM
The estimate for compound 4 lay 10-fold (1.01 log units) below the measured number; the whole stated range lies below it.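

On the core of compound 2, the change gives a 22-fold higher number from compound 2 to compound 4 (1.34 log units; beyond the scatter), so the size of the step seen on the core of compound 1 does not carry over: the same change on two cores in this assay, a 2.1-fold higher number (0.33 log units; beyond the scatter) from compound 1 to compound 3 and a 22-fold higher number (1.34 log units; beyond the scatter) from compound 2 to compound 4, 10-fold (1.01 log units) apart, beyond the scatter of two such steps In both pairs, methyl in place of hydrogen on the amine nitrogen gives a higher number, so the direction is shared by these two cores, though two pairs cannot establish a rule. Among these compounds, the pairs show that a step measured on one of these cores is a poor guide to its size on the other, but they do not show which feature of the cores sets the gap, and they cover only this one change in this assay.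

The compounds shown leave open whether ethyl on the same nitrogen, or a dimethylamino group in place of the amino group, would split the two cores in the same way. They also leave open whether a longer chain in place of the aminomethyl group would keep the same direction on both cores.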